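Extending the chain in a hydroxylated pyridine series

The compounds below may be only part of what the source reports. "The series", "measured", "known", "first", "only" and "open" are said of these compounds alone.

Three compounds in this set share a core carrying a hydroxy group, an amine and a long saturated chain, and were tested in a functional assay on cells (Lymphocyte, Homo sapiens), read by trypan blue exclusion, with a stated time of 16 h, tested at 0.5 uM; on this read-out lower numbers stand for a weaker effect and higher numbers for a stronger effect at the one concentration tested. Compound 1 `Cc1c(N(C)C)nc(CCCCCCCCCCO)c(O)c1C` gives 36% in this assay, compound 2 `CCCCCCCCCCc1nc(N(C)C)c(C)c(C)c1O` gives 77%, and compound 3 `CCCCCCCCCCCCCCCCc1c(C)c(N2CCC2)nc(C)c1O` gives 95%. Compound 2 therefore stands second highest of the three numbers, with compound 3 above it and compound 1 below.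

For the measured compounds named here, the one single-point step among the measured compounds is a number 41 percentage points higher from compound 1 to compound 2 (beyond the scatter). That step concerns the loss of a hydroxy group at the far end of the chain, not the length of the chain, so it bears only indirectly on the question here.

Compound 4 `CCCCCCCCCCCCCCCCCCCc1nc(N(C)C)c(C)c(C)c1O` differs from compound 2 by nonyl in place of hydrogen on a saturated chain carbon, ten or more bonds along the chain from an aromatic carbon. The closest guide is compound 3, which carries a longer chain than compound 2 and gives a higher number, although it also differs at the amine. With so little to go on, a step of modest size upward or none beyond the scatter is expected, estimated as a number 5 percentage points higher from compound 2 to compound 4 (within the scatter). Compound 4 is therefore expected to give about 82%, within a range of 60% to 96%.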

Compound 4, a percentage reported as activity, at one concentration (the size of the read-out at that concentration, not a potency): 7%
The estimate for compound 4 lay 75 percentage points above the measured number, outside the stated range (below it).
By their numbers in this assay, from the lowest: compound 4; then compound 1; then compound 2; then compound 3.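

Lengthening the chain by nonyl at this place does not carry the effect further upward: in this assay the change gives a large fall (a number 70 percentage points lower from compound 2 to compound 4 (beyond the scatter)). Hydrogen and nonyl therefore pull in opposite directions when each replaces the hydroxy of compound 1, for hydrogen gives a rise (a number 41 percentage points higher from compound 1 to compound 2 (beyond the scatter)) while nonyl gives a modest fall (a number 29 percentage points lower from compound 1 to compound 4 (beyond the scatter)), so at this place the outcome depends strongly on which group enters, and a much longer chain cannot be assumed to be tolerated. Nothing available here explains why the longer chain lowers the number.

These compounds leave open how the number changes with chain length between compound 2 and compound 4, which a butyl or a hexyl group in place of hydrogen at the same place would help to show. They also leave open whether a group other than hydroxy, such as a carboxylic acid or an amine on this saturated chain carbon, would give a number closer to that of compound 1 or to that of compound 2.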